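Swapping methyl for fluoro on a pyridinyl arm

The compounds below may be only part of what the source reports. "The series", "measured", "known", "first", "only" and "open" are said of these compounds alone.

Compound 1 `C=CC(=O)Nc1cccc(Nc2ncnc(Nc3ccc(C(=O)N4CCCCC4)cc3)n2)c1`: in a functional assay on Ramos cells (Homo sapiens) for antiproliferative activity, read by CCK-8 assay, with a stated time of 24 h (a higher number here means a weaker inhibitor, a lower number a stronger inhibitor), compound 1 gives 6140 nM.
Compound 2 `C=CC(=O)Nc1cccc(Nc2ncnc(Nc3ccc(Oc4ccc(OC)cc4)cc3)n2)c1`: in this assay compound 2 gives > 100000 nM, which is a limit of the assay and not a number.
Compound 3 `C=CC(=O)Nc1cccc(Nc2ncnc(Nc3ccc(-c4ccc(C)nc4)cc3)n2)c1`: in this assay compound 3 gives "not determined" (no result reported).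
Compound 4 `C=CC(=O)Nc1cccc(Nc2ncnc(Nc3ccc(-c4ccc(F)nc4)cc3)n2)c1`: not yet measured in this assay.

The four compounds share one core and differ only in the group on the outer aromatic ring. On these data alone, compound 3 stands with no number in this assay, so its place among the others is unknown. Within the data shown here, the single measured step, an at least 16-fold higher number from compound 1 to compound 2 (1.21 log units; beyond the scatter), is large; in that pair the second value is the limit of > 100000 nM in this assay, at which 1 of the 3 values shown sits.

Compound 4 differs from compound 3 by fluoro in place of methyl on an aromatic carbon. Among the measured compounds shown here, neither compound carries a measurement, so the only measured step, which concerns an unrelated change on the same ring, does not bear directly on this one. For the measured compounds named here, a change of one heavy atom for another is expected to shift the number little, but the starting point is unknown, so the estimate must lean on compound 1, the only numeric value, and stay wide. Compound 4 is estimated at 10000 nM, within 1500 nM to 100000 nM.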

Compound 4, half-maximal inhibitory concentration: 59200 nM
Compound 4: the middle estimate sits 5.9-fold (0.77 log units) below what was measured; low and high end bracket the measured number.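

Among these compounds, compound 4 gives the first number for a pyridinyl arm on the outer ring in this assay. Set against the (piperidin-1-yl)carbonyl arm, 6-fluoropyridin-3-yl reads as a 9.6-fold higher number from compound 1 to compound 4 (0.98 log units; beyond the scatter), so on this core the fluoropyridinyl arm gives the weaker inhibitor of that pair. Set against the 4-methoxyphenoxy arm, it reads as an at least 1.6-fold lower number from compound 2 to compound 4 (0.22 log units; that floor lies within the scatter), so no firm order can be given for that pair, and compound 2 holds a limit of the assay and not a number: the limit of > 100000 nM in this assay, at which 1 of the 4 values shown sits.

The change from 6-methylpyridin-3-yl to 6-fluoropyridin-3-yl itself cannot be read, as compound 3 has no result, and so nothing can be said about what fluoro does in place of methyl at this place. Open questions remain about whether an amine, a methoxy group or a nitrile on that same aromatic carbon would bring the number closer to that of compound 1, at 6140 nM, and about how a plain phenyl arm would compare with the pyridinyl arm.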